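Furan-2-yl in place of phenyl: note on compound 3

The source may hold more compounds than are shown below. What is called first, only, known or untested is meant among the compounds shown, and "the series" means these compounds.

Among the compounds with values here, compound 2 `COc1ccc(Nc2cc(-c3ccccc3)oc(=O)c2)cc1` holds the lower of the two numbers measured so far in a functional assay on A549 cells (Homo sapiens) for cytotoxicity, read by MTT assay, with a stated time of 72 h; a higher number here means that more compound is needed for the effect, a lower number that less compound is needed; in this assay compound 2 gives 0.093 uM. Within the data shown here, compound 1 `CCCCCc1cc(Nc2ccc(OC)cc2)cc(=O)o1` gives 4.42 uM in this assay, and the step of a 48-fold lower number from compound 1 to compound 2 (1.68 log units; beyond the scatter) is the only measured step in the set. Compound 3 `COc1ccc(Nc2cc(-c3ccco3)oc(=O)c2)cc1` has not yet been measured. The change is furan-2-yl in place of phenyl on an aromatic carbon. Among the measured compounds shown here, no measured step exchanges one aromatic ring for another at this carbon. For the measured compounds named here, the single step on record, from compound 1 to compound 2, replaces a pentyl chain by phenyl and is large, so it shows only that this position answers strongly to what is placed there, not how one aromatic ring compares with another. With the ring still aromatic and of similar size, a small step is expected in this assay, if any beyond the scatter, most likely a modest rise in the number. Compound 3 is therefore estimated at 0.18 uM, with a range from 0.05 uM to 0.6 uM. This amounts to an expected step of a 1.9-fold higher number from compound 2 to compound 3 (0.29 log units; within the scatter).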

Compound 3, concentration for half-maximal effect: 1.91 uM
Beside the measured number, compound 3's estimate is 11-fold (1.03 log units) below it; measured number outside the range, above it.
By their numbers in this assay, from the lowest: compound 2; then compound 3; then compound 1.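

In this assay, exchanging one aromatic ring for another at this carbon, next to the ring oxygen, is itself a large change (a 21-fold higher number from compound 2 to compound 3 (1.31 log units; beyond the scatter)), so the position separates phenyl from furan-2-yl and not only an aromatic ring from a pentyl chain. The low number of compound 2 therefore does not extend to every aromatic ring at this carbon: furan-2-yl keeps only a modest step over pentyl (a 2.3-fold lower number from compound 1 to compound 3 (0.36 log units; beyond the scatter)), and among these three compounds phenyl alone gives a number far below that of compound 1. No measurement at hand bears on the reason for this difference between phenyl and furan-2-yl.

The step from phenyl to furan-2-yl changes ring size and the ring oxygen together, so the compounds shown cannot say which of the two goes with the higher number; thiophen-2-yl and pyridin-2-yl at this carbon would separate them more finely. Whether the low number depends on an aromatic ring at all also stays open, as cyclohexyl, the saturated six-membered counterpart of phenyl, is not among the compounds shown.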